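The source may report more compounds than this note shows. Statements on the series, on what has been measured and on what is new or still open speak of the compounds shown alone.

Measured so far:
Compound 1, `CCCCCCC#Cc1c(CCCCCC)oc2nc(=O)n(Cc3cn(-c4ccc(F)cc4)nn3)cc12`: in an ADME assay on WI-38 cells (Homo sapiens) for antiproliferative activity, read by MTT assay, with a stated time of 72 h (on this read-out lower numbers stand for stronger inhibition and higher numbers for weaker inhibition), compound 1 gives > 100000 nM, which is a limit of the assay and not a number.
Compound 2, `CCCCCCC#Cc1c(CCCCCC)oc2nc(=O)n(Cc3cn(-c4ccc(Cl)cc4)nn3)cc12`: in this assay compound 2 gives > 100000 nM, again only a limit.

Where compound 2 stands: its reading is a limit, as is the one other value shown, so both sit at the limit of > 100000 nM in this assay, at which 2 of the 2 values shown sit. Among the compounds with values here, the single measured step, a step that the two limits leave unreadable from compound 1 to compound 2, is therefore not readable in size or direction; the two limits say only that neither compound reaches a measurable number.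

Compound 3 is `CCCCCCC#Cc1c(CCCCCC)oc2nc(=O)n(Cc3cn(Cc4ccccc4)nn3)cc12`. It differs from compound 2 as follows: benzyl in place of 4-chlorophenyl on an aromatic nitrogen. No measured step touches this change directly; the one step shown, a step that the two limits leave unreadable from compound 1 to compound 2, concerns a halogen exchange on the aromatic ring and gives no readable size. On the numbers shown there is no ground to expect a step beyond the scatter in this assay; the expected step of a number no higher from compound 2 to compound 3 (the limit leaves the size open) is none, and compound 3 is estimated to return a limit as well. The estimate for compound 3 is 100000 nM, with a range from 30000 nM to 300000 nM.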

Compound 3, half-maximal inhibitory concentration: 23400 nM
Compound 3: the middle estimate sits 4.3-fold (0.63 log units) above what was measured; the whole stated range lies above it.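

In this assay, the aromatic nitrogen of the five-membered aromatic ring with 3 nitrogen proves to be a place where the read-out can move, which the halogen exchange on the aromatic ring could not show, as its step cannot be read. Benzyl in place of 4-chlorophenyl gives an at least 4.2-fold lower number from compound 2 to compound 3 (0.63 log units; beyond the scatter), and benzyl in place of 4-fluorophenyl gives an at least 4.2-fold lower number from compound 1 to compound 3 (0.63 log units; beyond the scatter); both groups that leave and the benzyl that enters carry one six-membered aromatic ring of carbon only, so the ring itself is kept while its attachment and halogen change. Compound 3 is the only compound shown with a value that is not a limit: the limit of > 100000 nM in this assay, at which 2 of the 3 values shown sit.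

Going by these compounds, both steps are lower bounds and not full sizes, so how far the exchange really moves the number remains open. The change to benzyl also removes the halogen, and a 4-chlorobenzyl group or a longer chain such as 2-phenylethyl on the same nitrogen would be needed to tell whether the link to the ring or the loss of the halogen carries the step.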